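Lipophilicity notes: aryl replacements on the shared core

This account rests on a few compounds, and the source may have more. Where it says the series, first, only, none or still open, it means among the compounds named here.

Measured so far in a physicochemical assay for lipophilicity, using the shake flask method, in phosphate buffer, measured as octanol-water partition, with a stated time of 30 min, at pH 7.4; on this read-out lower numbers stand for lower lipophilicity and higher numbers for higher lipophilicity:
- compound 1, `CN(c1ccn(C)n1)c1cnc(NCc2c(F)ccc3c2CCO3)c2cn[nH]c(=O)c12`: 2.4
- compound 2, `Cc1nc(CN(C)C)ccc1-c1cnc(NCc2c(F)ccc3c2CCO3)c2cn[nH]c(=O)c12`: 2
- compound 3, `Cn1nccc1-c1cnc(NCc2c(F)ccc3c2CCO3)c2cn[nH]c(=O)c12`: 2.6

Compound 3 stands at the upper end of the three numbers. Its separation from compound 1, a number 0.20 log units higher from compound 1 to compound 3 (within the scatter), is within the scatter, so no order between those two is claimed; its separation from compound 2, a number 0.60 log units higher from compound 2 to compound 3 (beyond the scatter), is beyond the scatter, as is a number 0.40 log units lower from compound 1 to compound 2 (beyond the scatter).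

Compound 4, `Cc1ncccc1-c1cnc(NCc2c(F)ccc3c2CCO3)c2cn[nH]c(=O)c12`, is not yet measured. Its change from compound 3 is 2-methylpyridin-3-yl in place of 1-methyl-1H-pyrazol-5-yl on an aromatic carbon. For the measured compounds named here, the only measured step that bears on it is the pyrazole-to-pyridine exchange from compound 2 to compound 3, but compound 2 carries a 6-((dimethylamino)methyl) group that compound 4 lacks, and no step in the set isolates that group. Compound 4 is therefore expected to sit above compound 2 and modestly above compound 3, with the step of a number 0.40 log units higher from compound 3 to compound 4 (beyond the scatter) estimated as beyond the scatter but small. Compound 4 is estimated at 3, within 2.5 to 3.5.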

Compound 4, distribution coefficient: 3
Compound 4: middle estimate and measured number agree at the digits printed, and the stated range covers the measured number.
By their numbers in this assay, from the lowest: compound 2; then compounds 1 and 3 (each within the scatter of the next); then compound 4.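

In this assay, 2-methylpyridin-3-yl in place of 1-methyl-1H-pyrazol-5-yl on this aromatic carbon gives a number 0.40 log units higher from compound 3 to compound 4 (beyond the scatter) and, in place of methyl(1-methyl-1H-pyrazol-3-yl)amino, a number 0.60 log units higher from compound 1 to compound 4 (beyond the scatter), so compound 4 stands apart from two compounds that could not be ordered against each other. The (dimethylamino)methyl group now has a step of its own, since hydrogen in its place gives a number 1.00 log units higher from compound 2 to compound 4 (beyond the scatter) and this is the largest step in the set. The data shown offer no measured explanation for any of these steps.

As far as these compounds go, whether another amine, such as morpholine, or a carboxylic acid in that place would give a step of similar size remains open. The share of the methyl on the 2-methylpyridin-3-yl group also remains open, as no pair shown differs in that methyl alone.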